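The source may hold more compounds than are shown below. What is called first, only, known or untested is meant among the compounds shown, and "the series" means these compounds.

Measured so far:
compound 1 `COc1ccc2c(c1)/C(=N/NC(=S)Nc1ccccc1)C(=O)N2` — > 25000 nM
compound 2 `O=C1Nc2ccccc2/C1=N/NC(=S)Nc1ccc(Cl)cc1` — > 25000 nM

In an ADME assay on RD cells (Homo sapiens) for cytotoxicity (a lower number here means that less compound is tolerated, a higher number that more compound is tolerated), compound 1 gives > 25000 nM, which is a limit of the assay and not a number. Compound 2 likewise gives > 25000 nM, again a limit. Among the measured compounds shown here, compound 1 therefore stands at the limit of > 25000 nM in this assay, at which 2 of the 2 values shown sit, and both values shown sit there; no pair of measured compounds differs in one place, so no measured step gives a direction or a size.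

Compound 3 `O=C1Nc2ccc(F)cc2/C1=N/NC(=S)Nc1ccccc1` differs from compound 1 by fluoro in place of methoxy on an aromatic carbon. No step beyond the scatter is expected in this assay in either direction, since compound 1 stands at the limit of > 25000 nM in this assay, at which 2 of the 2 values shown sit, with nothing to move from. For compound 3 the estimate is 30000 nM, within 10000 nM to 100000 nM, most probably reported as a limit once more. The expected step is a step that the limit leaves unreadable from compound 1 to compound 3.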

Compound 3, half-maximal cytotoxic concentration: > 25000 nM
Compound 3 gave a limit, no number (the forecaster's own chance of this, stated with the estimate: 75%); the middle value does not contradict the limit.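

No step can be read from compound 1 to compound 3 in this assay, as both values are limits and not numbers: the limit of > 25000 nM in this assay, at which 3 of the 3 values shown sit.

The compounds shown leave open how far each lies from that limit, and whether any change on the shared core gives a readable value.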